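The source may report more compounds than this note shows. Statements on the series, on what has been measured and on what is new or still open speak of the compounds shown alone.

Compound 1 `COc1ccc(/C=C/c2ccc3ccccc3c2)cc1`: > 5000 nM
Compound 2 `COc1cccc(/C=C\c2ccc3ccccc3c2)c1`: 1920 nM
Compound 3 `FC(F)(F)Oc1ccc(/C=C/c2ccc3ccccc3c2)cc1`: > 5000 nM

In a functional assay on HCT-116 cells (Homo sapiens) for inhibition (a higher number here means a weaker inhibitor, a lower number a stronger inhibitor), compound 1 gives > 5000 nM, which is a limit of the assay and not a number. Compound 3 likewise gives > 5000 nM in this assay, again a limit rather than a number. Compound 2 is the only one of the three with a measured number, 1920 nM in this assay. Compound 2 and compound 1 have the same atoms joined differently; the difference between the two cores is not broken down here.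

From compound 1 to compound 3 the change is trifluoromethyl in place of methyl on an oxygen on an aromatic ring. The step that the two limits leave unreadable from compound 1 to compound 3 cannot be read, since both ends sit at the limit of > 5000 nM in this assay, at which 2 of the 3 values shown sit.

Compound 4 `FC(F)(F)Oc1cccc(/C=C\c2ccc3ccccc3c2)c1` carries the same change from compound 2, (trifluoromethyl in place of methyl on an oxygen on an aromatic ring), at a place described in the same words. Among the compounds with values here, with the only earlier instance of this change unreadable, the step of a 1.3-fold higher number from compound 2 to compound 4 (0.11 log units; within the scatter) is expected to be small, and this rests on compound 2 at 1920 nM as the only anchor. Compound 4 is therefore estimated at 2500 nM, between 800 nM and 8000 nM.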

Compound 4, half-maximal inhibitory concentration: 3500 nM
Compound 4: middle estimate off by 1.4-fold (0.15 log units), on the low side; measured number inside the range.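

In this assay, the methoxy to trifluoromethoxy change on the core of compound 2 gives a 1.8-fold higher number from compound 2 to compound 4 (0.26 log units; within the scatter), so on this core the two compounds cannot be told apart. On the core of compound 1 the same change cannot be read, since compound 1 and compound 3 each give a limit of the assay and not a number: the limit of > 5000 nM in this assay, at which 2 of the 4 values shown sit. The series therefore holds a single readable instance of this change, which does not show that the result carries from one core to the other or that the two cores respond alike.

Going by these compounds, it remains open whether a longer chain on that oxygen, or an amine or a carboxylic acid in place of the methoxy, would give a number clearly apart from that of compound 2, at 1920 nM. What the difference between the two cores contributes by itself also stays open; no pair shown isolates it.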